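This account rests on a few compounds, and the source may have more. Where it says the series, first, only, none or still open, it means among the compounds named here.

Measured so far in an ADME assay on L1210/0 cells (Mus musculus) for cytotoxicity, with a stated time of 48 h; a higher number here means a weaker inhibitor, a lower number a stronger inhibitor:

- Compound 1 `COc1ccc(-c2ncnc3c2ncn3C[C@@H]2C[C@H](CO)c3ccccc32)cc1`: 17600 nM
- Compound 2 `Nc1nc2c(nc(I)n2COCCO)c(=O)[nH]1`: 111000 nM
- Compound 3 `CC(C)Nc1ncnc2c1ncn2C1C[C@@H](CO)[C@@H](CO)C1`: > 200000 nM

Compound 3 has a limit of the assay, not a number. Of the two true numbers, compound 1 has the lower, 17600 nM. Compound 2 gives 111000 nM, and that gap lies beyond the usual scatter. Compound 1 is therefore the stronger inhibitor of this pair.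

The next compound, compound 4 `CCOc1ncnc2c1ncn2C[C@@H]1C[C@H](CO)c2ccccc21`, keeps the core of compound 1 but changes one group. It has ethoxy in place of 4-methoxyphenyl on an aromatic carbon. The change sits on a six-membered aromatic ring with 2 nitrogen, part of a fused or bridged system of two rings.

Going by the values given here, no two measured compounds differ in just one place, so the expectation rests on thin ground. Only compound 1 carries 4-methoxyphenyl, and compound 2, which lacks it and differs in much else, gives 111000 nM. That is a hint and not a pattern, but it points towards a weaker inhibitor. An estimated change beyond the scatter is expected, a 3.4-fold higher number from compound 1 to compound 4 (0.53 log units; beyond the scatter). For compound 4 the expected value is 60000 nM, with an estimated range of 15000 nM to 200000 nM.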

Compound 4, half-maximal inhibitory concentration: > 200000 nM
Compound 4: a limit, no number; the forecaster's own chance of this, stated with the estimate: 25%; middle value at least 3.3-fold (0.52 log units) away from the limit.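

In this assay compound 4 gives > 200000 nM, which is a limit of the assay and not a number. Going by these compounds alone, this is the first comparison here between two compounds that differ in one place, and it shows that the group on this aromatic carbon of the shared core matters: ethoxy in place of 4-methoxyphenyl gives an at least 11-fold higher number from compound 1 to compound 4 (1.05 log units; beyond the scatter). That step is only a minimum, and its full size cannot be read, because the result reaches the end of the measurable range: the limit of > 200000 nM in this assay, at which 2 of the 4 values shown sit.

The compounds shown leave open which feature of 4-methoxyphenyl goes with the lower number: its aromatic ring of carbon, the methoxy on that ring, or simply its larger count of heavy atoms. A plain phenyl on the same aromatic carbon would test whether the methoxy is needed, while a longer chain such as hexyloxy would test whether a larger group without a ring can restore a measurable value.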